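The source may report more compounds than this note shows. Statements on the series, on what has been measured and on what is new or still open speak of the compounds shown alone.

Compound 1 `CCCOC(=O)C1=C(C)N(C)C(=O)NC1c1ccco1` and compound 2 `CC1=C(C(=O)OCC(C)C)C(c2ccco2)NC(=O)N1C` share one core. In an assay on membranes from CHO cells for displacement of a labelled ligand from adenosine receptor A1 (Homo sapiens), read by scintillation counting, with a stated time of 60 min, tested at 1 uM (a higher number here means more inhibition at the concentration tested (going by the name of the read-out), a lower number less inhibition), compound 1 gives 3%, and compound 2 gives 13%, a step of a number 10 percentage points higher from compound 1 to compound 2 (within the scatter) that goes with methyl in place of hydrogen on a saturated chain carbon bound to two saturated chain carbons. Compound 3 `CCSC(=O)C1=C(C)NC(=O)NC1c1ccoc1` is built on a different core; the difference between the two cores is not broken down here. In this assay compound 3 gives 3%, level with compound 1 and within the scatter of compound 2. Compound 4 `CC1=C(C(=O)SC(C)C)C(c2ccoc2)NC(=O)N1` carries methyl in place of hydrogen on a saturated chain carbon bound to a saturated chain carbon and a sulfur, the same kind of change as that from compound 1 to compound 2, though not the same: here the carbon is bound to a saturated chain carbon and a sulfur rather than to two saturated chain carbons. Because a number 10 percentage points higher from compound 1 to compound 2 (within the scatter) stayed within the scatter, compound 4 is expected to shift by only a number 5 percentage points higher from compound 3 to compound 4 (within the scatter) and to read about 8%, estimated between 0% and 25%.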

Compound 4, a percentage reported as inhibition, at one concentration (the size of the read-out at that concentration, not a potency): 9%
Estimate against measurement, compound 4: 1 percentage points below, within the range that was stated.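

Going from ethylsulfanyl to isopropylsulfanyl gives a number 6 percentage points higher from compound 3 to compound 4 (within the scatter) in this assay. Set beside the earlier step, the same kind of change reads alike on the two cores: the same change on two cores in this assay, a number 10 percentage points higher (within the scatter) from compound 1 to compound 2 and a number 6 percentage points higher (within the scatter) from compound 3 to compound 4, 4 percentage points apart, within the scatter of two such steps. This shows no difference between the cores for this change, but it does not show that the change moves the reading on either core, since both steps lie within the scatter, and the carbon that takes the methyl is not bound to the same atoms in the two cases.

The compounds shown leave open what a longer chain or an amine at this place would read in this assay. They also leave open how the change would behave on any third core.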